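A few compounds are considered here, and "the series" means these few. Any claim that something is new, unique, unknown or untested is made for them only; others in the source may bear on it.

Two compounds of this series have numbers in an assay for inhibition of very long chain fatty acid elongase 6 (Homo sapiens); a lower number here means a stronger inhibitor, a higher number a weaker inhibitor. Compound 1, `O=C(Nc1ccc(F)cc1)OCC1(C(F)(F)F)OC(=O)Nc2ccc(Cl)cc21`, gives 142 nM. Compound 2, `O=C1Nc2ccccc2C(CNC(=O)c2ccc(F)cc2)(C(F)(F)F)O1`, gives 95 nM; this is the lowest of the two numbers, but it lies within the scatter of compound 1, so the two cannot be placed in order on these data. Compound 3, `O=C1Nc2ccc(-c3ccon3)cc2C(CNC(=O)c2ccc(F)cc2)(C(F)(F)F)O1`, has not yet been measured in this assay; it differs from compound 2 by 1,2-oxazol-3-yl in place of hydrogen on an aromatic carbon. Among the measured compounds shown here, no step between measured compounds bears on this change, and there is nothing to say whether such a group raises or lowers the number. The working expectation is therefore a step of modest size, if any, from compound 2 to compound 3 in this assay, a 1.6-fold lower number from compound 2 to compound 3 (0.20 log units; within the scatter), with either direction possible. Compound 3 is accordingly expected to give about 60 nM, the range running from 15 nM to 250 nM.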

Compound 3, half-maximal inhibitory concentration: 121 nM
Compound 3: the middle estimate sits 2.0-fold (0.30 log units) below what was measured; low and high end bracket the measured number.
By their numbers in this assay, from the lowest: compounds 2, 3 and 1 (each within the scatter of the next).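

In this assay, among the compounds shown here, the change of hydrogen to 1,2-oxazol-3-yl gives a 1.3-fold higher number from compound 2 to compound 3 (0.11 log units; within the scatter) and is the first readable step. It shows that this aromatic carbon, para to a fused ring, can carry a five-membered aromatic ring of 5 heavy atoms with a step that stays within the scatter, so the number does not separate compound 3 from compound 2. No measurement at hand accounts for the size of this step.

Still open, going by these compounds, is whether the same position gives steps beyond the scatter with other groups, such as an amine, a carboxylic acid or a phenyl ring. Also open, on these data alone, is whether 1,2-oxazol-3-yl gives a similar step when the amide chain of compound 2 is replaced by a longer chain.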